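The source may report more compounds than this note shows. Statements on the series, on what has been measured and on what is new or still open speak of the compounds shown alone.

In a functional assay on IC2 cells (Mus musculus) for cytotoxicity, read by MTT assay, with a stated time of 72 h (a lower number here means a stronger inhibitor, a higher number a weaker inhibitor), compound 2 (`CNC1=C(Br)C(=O)c2ccncc2C1=O`) gives 0.22 ug/mL and compound 3 (`CNC1=C(Cl)C(=O)c2ccncc2C1=O`) gives 0.28 ug/mL as its reading. Compound 1 (`O=C1C=C(NCCO)C(=O)c2cnccc21`) gives 1.67 ug/mL as the third number, so compound 3 stands with compound 2 at the low end of the three and clearly under compound 1.

Next is compound 4 (`CNC1=CC(=O)c2ccncc2C1=O`) with the change hydrogen in place of chloro on a double-bonded ring carbon in which hydrogen takes the place of chloro on a double-bonded ring carbon, next to the ring atom that bears a methylamino group. Within the data shown here, one measured step bears on that carbon: a 1.3-fold higher number from compound 2 to compound 3 (0.10 log units; within the scatter) is small, but it only trades one halogen for another. Among the measured compounds shown here, no measured step removes the halogen. For the measured compounds named here, compound 1 is the only measured compound without one, and its 1.67 ug/mL offers a loose upper guide, though no single-place step links it to compound 3.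

A moderately higher number in this assay is therefore expected, with wide uncertainty. The expected step is a 2.9-fold higher number from compound 3 to compound 4 (0.46 log units; beyond the scatter) as an estimate only. For compound 4 the estimated value is 0.8 ug/mL with an expected range of 0.25 ug/mL to 2.5 ug/mL as its ends.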

Compound 4, half-maximal inhibitory concentration: 0.34 ug/mL
Compound 4: the middle estimate sits 2.4-fold (0.37 log units) above what was measured, and the stated range covers the measured number.
By their numbers in this assay, from the lowest: compounds 2, 3 and 4 (each within the scatter of the next); then compound 1.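

In this assay, removing the halogen from the double-bonded ring carbon gives a 1.2-fold higher number from compound 3 to compound 4 (0.08 log units; within the scatter) and, starting from the bromo compound, a 1.5-fold higher number from compound 2 to compound 4 (0.19 log units; within the scatter), so chloro, bromo and hydrogen cannot be told apart at this place among these three compounds. A halogen on this carbon is therefore not required for a reading at the low end of this small set, and the earlier halogen swap had not shown this. Among these compounds, the only step beyond the scatter here is a 4.9-fold lower number from compound 1 to compound 4 (0.69 log units; beyond the scatter), a change on the chain bound to the amine nitrogen, so the gap to compound 1 cannot be attributed to the absence of a halogen.

No measurement available here gives a reason for any of these readings. Still open, as far as these compounds go, is whether a group other than hydrogen, chloro or bromo on this carbon, such as a nitrile, a methoxy or an amine, would move the reading beyond the scatter, and whether a longer chain in place of the methylamino group would do so.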